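This account rests on a few compounds, and the source may have more. Where it says the series, first, only, none or still open, it means among the compounds named here.

Compound 1 `Cc1ccc(C(=O)/C=C/c2ccc(N3CCCCC3)cc2)s1`: 21200 nM
Compound 2 `c1csc(C2=NNC(c3ccc(N4CCCCC4)cc3)C2)c1`: 6900 nM

In an ADME assay on CCRF-CEM cells (Homo sapiens) for cytotoxicity, with a stated time of 5 days (a higher number here means a weaker inhibitor, a lower number a stronger inhibitor), compound 2 gives 6900 nM, the lowest of the two numbers measured, while compound 1 gives 21200 nM, a higher number that lies beyond the usual scatter of this measurement. Compound 3 `Clc1cc(C2=NNC(c3ccc(N4CCCCC4)cc3)C2)c(Cl)s1` has not yet been measured. It differs from compound 2 in a single place: 2,5-dichlorothiophen-3-yl in place of thiophen-2-yl on a carbon with a double bond to nitrogen. Among the measured compounds shown here, no pair of measured compounds shows the effect of such a swap on its own, so the expectation for compound 3 in this assay has to rest on the number of compound 2 alone. The step expected from this change is a small one toward a lower number, a 1.5-fold lower number from compound 2 to compound 3 (0.19 log units; within the scatter), not clearly beyond the scatter. For compound 3 in this assay the estimate is 4500 nM, with a likely range from 1200 nM to 18000 nM.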

Compound 3, half-maximal inhibitory concentration: 37700 nM
Estimate against measurement, compound 3: 8.4-fold (0.92 log units) below; the measured number lies above the stated range.
By their numbers in this assay, from the lowest: compound 2; then compounds 1 and 3 (each within the scatter of the next).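

Among the compounds shown here, the first measured swap at this place shows that the group on the carbon with a double bond to nitrogen affects the result in this assay: 2,5-dichlorothiophen-3-yl in place of thiophen-2-yl gives a 5.5-fold higher number from compound 2 to compound 3 (0.74 log units; beyond the scatter), so compound 3 is the weaker inhibitor, and the step lies beyond the usual scatter. The swap makes two changes at once, adding two chlorine atoms and moving the thiophene link from the 2-yl to the 3-yl form, so this single step cannot separate their contributions. Nothing measured here explains the loss of activity.

As far as these compounds go, it remains open how this place would respond to a thiophen-3-yl group without chlorine, or to a thiophen-2-yl group carrying one chlorine. A phenyl or pyridinyl group here is also untested in the compounds shown, so the range of groups compatible with activity is unknown.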